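The compounds below may be only part of what the source reports. "The series", "measured", "known", "first", "only" and "open" are said of these compounds alone.

Compound 1 `Cc1ccc(C(=O)NC(=N)N(C)Sc2cccc(C)c2)cc1` gives 5440 nM in an assay on CHO cells for inhibition of sodium channel protein type 2 subunit alpha (Homo sapiens); a higher number here means a weaker inhibitor, a lower number a stronger inhibitor. Compound 2 `N=C(NCCCCc1ccccc1)NC(=O)c1cccc(Cl)c1Cl` gives 1480 nM in this assay, and compound 3 `N=C(NCCCCc1ccccc1)NC(=O)c1c(Cl)cccc1Cl` gives 5030 nM. For the measured compounds named here, of the three numbers, the value of compound 3 sits close to that of compound 1, within the usual scatter, while the only step beyond the scatter is the one from compound 2 to compound 3, a 3.4-fold higher number from compound 2 to compound 3 (0.53 log units; beyond the scatter), which changes just the chlorine pattern on the ring attached to the carbonyl carbon.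

Compound 4 `N=C(NCCCCc1ccccc1)NC(=O)c1ccco1` carries a different ring at that same position: furan-2-yl in place of 2,6-dichlorophenyl on a carbonyl carbon. Going by the values given here, the one measured step that bears on this site, a 3.4-fold higher number from compound 2 to compound 3 (0.53 log units; beyond the scatter), concerns a rearrangement of two chlorines and reached only a modest size; no measured step covers exchanging the dichlorinated six-membered ring for a five-membered ring with one hetero atom. With the shared chain and acyl guanidine unchanged, the step expected in this assay from compound 3 to compound 4 is a 1.4-fold higher number from compound 3 to compound 4 (0.14 log units; within the scatter), a change that may well stay within the scatter, with a higher number somewhat more likely than a lower one. Compound 4 is therefore estimated at 7000 nM in this assay, with a range from 2000 nM to 25000 nM.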

Compound 4, half-maximal inhibitory concentration: 13800 nM
Beside the measured number, compound 4's estimate is 2.0-fold (0.29 log units) below it; low and high end bracket the measured number.
By their numbers in this assay, from the lowest: compound 2; then compounds 3 and 1 (each within the scatter of the next); then compound 4.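

Exchanging the whole ring on the carbonyl carbon, rather than only moving its chlorines, shifts the number beyond the scatter in this assay: furan-2-yl in place of 2,6-dichlorophenyl gives a 2.7-fold higher number from compound 3 to compound 4 (0.44 log units; beyond the scatter) and, in place of 2,3-dichlorophenyl, a 9.3-fold higher number from compound 2 to compound 4 (0.97 log units; beyond the scatter) on the same chain. The position therefore responds to more than the chlorine pattern, and among the three compounds with this chain, the one carrying furan-2-yl has the highest number, with both dichlorophenyl compounds lower. No measurement at hand gives a reason for this difference.

The change from either dichlorophenyl group to furan-2-yl alters several things at once: the chlorines leave, the six-membered ring of carbon only becomes a five-membered ring, and an oxygen enters, so the compounds shown cannot assign the higher number to any one of these. A plain phenyl group would show what the chlorines alone contribute, and a thiophen-2-yl group would show whether the five-membered ring keeps this number when sulfur stands in place of the oxygen.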